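Removing the methylsulfonyl group from the benzamide ring

The source may hold more compounds than are shown below. What is called first, only, known or untested is meant among the compounds shown, and "the series" means these compounds.

Measured so far:
compound 1 `Cc1cc(Cl)ccc1C(=O)Nc1ccc(Cl)c(-c2nnc3c(Cl)cccn23)c1` 34300 nM
compound 2 `O=C(Nc1ccc(Cl)c(-c2nnc3c(Cl)cccn23)c1)c1ccc(Cl)cc1Cl` 21600 nM
compound 3 `CS(=O)(=O)c1ccc(C(=O)Nc2ccc(Cl)c(-c3nnc4c(Cl)cccn34)c2)c(Cl)c1` > 100000 nM

In a functional assay on MDA-MB-468 cells (Homo sapiens) for antiproliferative activity, read by MTT assay, with a stated time of 72 h (on this read-out lower numbers stand for stronger inhibition and higher numbers for weaker inhibition), compound 3 gives > 100000 nM, which is a limit of the assay and not a number; it sits at the limit of > 100000 nM in this assay, at which 1 of the 3 values shown sits. Compound 4 `O=C(Nc1ccc(Cl)c(-c2nnc3c(Cl)cccn23)c1)c1ccccc1Cl` differs from compound 3 by hydrogen in place of methylsulfonyl on an aromatic carbon. The step bearing on this is an at least 4.6-fold higher number from compound 2 to compound 3 (0.66 log units; beyond the scatter), where the methylsulfonyl group entered. The step of a 1.6-fold lower number from compound 1 to compound 2 (0.20 log units; within the scatter) touched another position. Taking the methylsulfonyl group away again is therefore expected to move the number back down, by about an at least 3.3-fold lower number from compound 3 to compound 4 (0.52 log units; beyond the scatter). Compound 4 is estimated at 30000 nM, with a range from 10000 nM to 100000 nM.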

Compound 4, half-maximal inhibitory concentration: > 100000 nM
Compound 4: a limit, no number; the forecaster's own chance of this, stated with the estimate: 20%; at least 3.3-fold (0.52 log units) between middle value and limit.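

In this assay compound 4 gives > 100000 nM, a limit of the assay and not a number. Hydrogen in place of chloro at this carbon gives an at least 4.6-fold higher number from compound 2 to compound 4 (0.66 log units; beyond the scatter), and 2-chlorophenyl in place of 4-chloro-2-methylphenyl gives an at least 2.9-fold higher number from compound 1 to compound 4 (0.46 log units; beyond the scatter), so a high number here does not require methylsulfonyl. The step from compound 3 to compound 4 cannot be read, since both values are limits: the limit of > 100000 nM in this assay, at which 2 of the 4 values shown sit.

Open, on these data alone, is how far apart hydrogen and methylsulfonyl actually lie at this carbon. Also open, as far as these compounds go, is whether an amine or a carboxylic acid here would keep a measurable number, as chloro does in compound 2.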